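Bromo to Methyl at the Assay Limit

A few compounds are considered here, and "the series" means these few. Any claim that something is new, unique, unknown or untested is made for them only; others in the source may bear on it.

In a physicochemical assay for pharmacokinetics (a lower number here means that the compound disappears faster, a higher number that the compound lasts longer), compound 1 `O=C(NCc1ccccc1Br)N1C(=O)c2ccccc2S1(=O)=O` gives > 166 h, which is a limit and not a number. Compound 2 `O=C(NCc1ccc(C(F)(F)F)cc1)N1C(=O)c2ccccc2S1(=O)=O` gives > 166 h, also a limit. Compound 3 `O=C(OCc1ccccc1)N1C(=O)c2ccccc2S1(=O)=O` gives > 166 h, again a limit. Compound 1 therefore stands at the limit of > 166 h in this assay, at which 3 of the 3 values shown sit. Compound 4 `Cc1ccccc1CNC(=O)N1C(=O)c2ccccc2S1(=O)=O` carries methyl in place of bromo on an aromatic carbon, ortho to a large group: methyl in place of bromo on an aromatic carbon. For the measured compounds named here, no measured pair shows this change. With compound 1 at > 166 h, a limit, no step beyond the scatter is expected in either direction. The expected step, a step that the limit leaves unreadable from compound 1 to compound 4, is only an estimate. Compound 4 is expected to show about 200 h, with an estimated range of 110 h to 400 h.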

Compound 4, half-life: > 166 h
Compound 4: a limit, no number; the forecaster's own chance of this, stated with the estimate: 70%; the middle value lies beyond the limit too.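

Compound 1 and compound 4 both stop at a limit, so no step from bromo to methyl can be read in this assay: the limit of > 166 h in this assay, at which 4 of the 4 values shown sit.

How long any of these compounds actually lasts, and whether bromo and methyl differ at all, stays open.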